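Replacing bromo with trifluoromethyl in the 3-bromobenzyl group

The source may hold more compounds than are shown below. What is called first, only, known or untested is meant among the compounds shown, and "the series" means these compounds.

In a functional assay on HCT-116 cells (Homo sapiens) for antiproliferative activity, read by MTT assay, with a stated time of 24 h (a lower number here means a stronger inhibitor, a higher number a weaker inhibitor), compound 1 (`COc1cc(OC)c(-c2coc3cc(OCc4ccc(C#N)cc4)ccc3c2=O)cc1OC`) gives 4220 nM and compound 2 (`COc1cc(OC)c(-c2coc3cc(OCc4ccc(Cl)cc4)ccc3c2=O)cc1OC`) gives 4450 nM. The two do not separate, as a 1.1-fold higher number from compound 1 to compound 2 (0.02 log units; within the scatter) stays within the scatter. Compound 3 (`COc1cc(OC)c(-c2coc3cc(OCc4cccc(Br)c4)ccc3c2=O)cc1OC`) stands lowest of the three at 1200 nM. It is reached by a 3.5-fold lower number from compound 1 to compound 3 (0.55 log units; beyond the scatter) and by a 3.7-fold lower number from compound 2 to compound 3 (0.57 log units; beyond the scatter), both modest and beyond the scatter.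

Compound 4 (`COc1cc(OC)c(-c2coc3cc(OCc4cccc(C(F)(F)F)c4)ccc3c2=O)cc1OC`) differs from compound 3 at a single place: trifluoromethyl in place of bromo on an aromatic carbon. Trifluoromethyl stands in place of bromo on an aromatic carbon, meta to a large group. Among the measured compounds shown here, no measured step makes this exchange. The two steps into compound 3 alter both the group and its place, so they cannot show what the group alone contributes. For the measured compounds named here, the one step that swaps one group for another at the same place, a 1.1-fold higher number from compound 1 to compound 2 (0.02 log units; within the scatter), lies within the scatter, and it is the closest guide here. On that basis, no change beyond the scatter is expected, with only a slight lean towards a higher number in this assay. The expected step is a 1.4-fold higher number from compound 3 to compound 4 (0.15 log units; within the scatter). The estimate for compound 4 is 1700 nM, with an expected range from 700 nM to 4200 nM.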

Compound 4, half-maximal inhibitory concentration: 3400 nM
Compound 4: the middle estimate sits 2.0-fold (0.30 log units) below what was measured; measured number inside the range.
By their numbers in this assay, from the lowest: compound 3; then compounds 4, 1 and 2 (each within the scatter of the next).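

Among the compounds shown here, the exchange of bromo for trifluoromethyl isolates the group at this position for the first time, since the earlier steps into compound 3 changed group and place together. In this assay, a 2.8-fold higher number from compound 3 to compound 4 (0.45 log units; beyond the scatter) shows that with the place held constant, the group on this aromatic carbon still matters, and that the lower number of compound 3 does not come from the place alone. Compound 4 also does not separate from the other two compounds, with a 1.3-fold lower number from compound 2 to compound 4 (0.12 log units; within the scatter) and a 1.2-fold lower number from compound 1 to compound 4 (0.09 log units; within the scatter), so among these four compounds only the 3-bromobenzyl group stands apart, and nothing at hand gives a reason for that difference.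

From the compounds shown here alone, whether a methoxy group, an amine or a plain hydrogen in the place of bromo would stay with compound 3 or fall in with compounds 1, 2 and 4 remains open. Also open, going by these compounds, is whether bromo would keep its lower number on the ring carbon that carries chloro in compound 2, which would show how far group and place act separately.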